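This account rests on a few compounds, and the source may have more. Where it says the series, first, only, none or still open, it means among the compounds named here.

Series notes. Compound 1 `CN1CCCC(NS(=O)(=O)c2ccccc2Nc2cc(-c3ccc4ccn(C)c4c3)c3nccnc3c2)C1` and compound 2 `CN1CCC(NC(=O)c2ccncc2Nc2cc(-c3ccc4ccn(C)c4c3)c3nccnc3c2)CC1=O` share the same core and differ in the side chain carried on the core. In an assay for inhibition of 6-phosphofructo-2-kinase/fructose-2,6-bisphosphatase 3 (Homo sapiens), read by ADP-Glo, with a stated time of 2 h (on this read-out higher numbers stand for weaker inhibition and lower numbers for stronger inhibition), compound 1 gives 59 nM. In this assay compound 2 gives 41 nM, the lower of the two numbers; the gap to compound 1 is within the scatter, so the two are treated as equivalent here.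

Compound 3 `CN1CCC(N(C)C(=O)c2ccncc2Nc2cc(-c3ccc4ccn(C)c4c3)c3nccnc3c2)C1` is the next analogue of compound 2. The change is methyl(1-methylpyrrolidin-3-yl)amino in place of (1-methyl-2-oxopiperidin-4-yl)amino on a carbonyl carbon. The group that leaves carries one hydrogen-bond donor; the group that enters carries none, and the ring size drops from six to five.

Among the measured compounds shown here, no step between measured compounds is available for this kind of change, so the expectation rests on compound 2 alone, at 41 nM. A modest shift toward a higher number is expected for compound 3, with the step of a 1.8-fold higher number from compound 2 to compound 3 (0.26 log units; within the scatter) likely to stay near the edge of the scatter. Compound 3 is estimated at 75 nM, in the range 20 nM to 300 nM.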

Compound 3, half-maximal inhibitory concentration: 176 nM
Compound 3: the middle estimate sits 2.3-fold (0.37 log units) below what was measured; the range from low to high includes it.
By their numbers in this assay, from the lowest: compounds 2 and 1 (each within the scatter of the next); then compound 3.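

In this assay the group on the carbonyl carbon is not indifferent to change: methyl(1-methylpyrrolidin-3-yl)amino in place of (1-methyl-2-oxopiperidin-4-yl)amino gives a 4.3-fold higher number from compound 2 to compound 3 (0.63 log units; beyond the scatter) and this is the only step shown that lies beyond the scatter. The change alters several features at once, namely the ring size, the ring carbonyl and the hydrogen-bond donor, so this one step cannot be divided among them. Nothing available here bears on why the number rises.

Which of these features carries the step remains open. (1-Methylpyrrolidin-3-yl)amino, methyl(1-methyl-2-oxopiperidin-4-yl)amino and (1-methylpiperidin-4-yl)amino on the same carbonyl carbon would each separate one feature from the others.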